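The source may report more compounds than this note shows. Statements on the series, on what has been measured and on what is new or still open speak of the compounds shown alone.

In a functional assay on MDA-MB-468 cells (Homo sapiens) for antiproliferative activity (a higher number here means a weaker inhibitor, a lower number a stronger inhibitor), compound 1 `CC(=O)N(C(C)=O)c1ccc(-c2nc3ccccc3s2)cc1` gives > 100 nM, which is a limit and not a number. Compound 2 `CC(=O)N(C(C)=O)c1ccc(-c2nc3ccccc3s2)cc1Cl`, which carries an added chloro group, gives > 1000 nM, also a limit. Among the measured compounds shown here, the one measured step, a step that the two limits leave unreadable from compound 1 to compound 2, has no readable size and is a different change, so it sets no firm expectation. Compound 3 `O=C(CCl)Nc1ccc(-c2nc3ccccc3s2)cc1` is altered elsewhere: ((chloromethyl)carbonyl)amino in place of diacetylamino on an aromatic carbon. The expected step, a step that the limit leaves unreadable from compound 1 to compound 3, is therefore only a loose estimate, leaning toward a weaker inhibitor. For compound 3 the estimated value is 1000 nM, with an expected range of 150 nM to 7000 nM.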

Compound 3, half-maximal inhibitory concentration: > 100 nM
Compound 3 gave a limit, no number; the forecaster's own chance of this, stated with the estimate: 40%; the middle value does not contradict the limit.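

Compound 1 and compound 3 both give limits rather than numbers in this assay, so no step can be read between them. The compounds shown leave open whether ((chloromethyl)carbonyl)amino in place of diacetylamino changes the antiproliferative activity at all.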